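Phenyl in place of pyridinylmethyl: compound 4 in clearance

A few compounds are considered here, and "the series" means these few. Any claim that something is new, unique, unknown or untested is made for them only; others in the source may bear on it.

Compound 1 `O=C(NCc1cc(Cl)ccc1-n1cnnn1)[C@@H]1C[C@@H]2C[C@@H]2N1C(=O)[C@H](O)Cc1ccccn1` has been tested in an ADME assay on liver for metabolic stability, with Liver microsome (Homo sapiens) as the target, read by LC-MS, using microsomes (a lower number here means slower removal, a higher number faster removal of the compound), where compound 1 gives 17 mL.min-1.g-1. Among the measured compounds shown here, this is the only plain number among the three measured compounds; the other two results are limits of the assay rather than numbers. Compound 2 `CCCC[C@@H](O)C(=O)N1N=CC[C@H]1C(=O)NCc1cc(Cl)ccc1-n1cnnn1` reaches such a limit, and compound 2 gives < 12 mL.min-1.g-1. Compound 3 `CC(C)(C)[C@@H](O)C(=O)N1N=CC[C@H]1C(=O)NCc1cc(Cl)ccc1-n1cnnn1` reaches a limit as well, and compound 3 gives < 12 mL.min-1.g-1. For the measured compounds named here, the single step between measured compounds, a step that the two limits leave unreadable from compound 2 to compound 3, cannot be read for that reason, and the limit of < 12 mL.min-1.g-1 in this assay, at which 2 of the 3 values shown sit, marks the floor at which two of the three results sit.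

Compound 4 `O=C(NCc1cc(Cl)ccc1-n1cnnn1)[C@@H]1C[C@@H]2C[C@@H]2N1C(=O)[C@H](O)c1ccccc1` differs from compound 1 in one place: phenyl in place of (pyridin-2-yl)methyl on a saturated chain carbon bound to a carbonyl carbon and an oxygen on a saturated carbon. Going by the values given here, no measured step bears directly on this change. The only step shown concerns a different pair of groups at the same place, a saturated chain carbon bound to a carbonyl carbon and an oxygen on a saturated carbon, and its size is not readable. Among the compounds with values here, with compound 1 already close to the floor and no step to give a direction, compound 4 is expected to remain within the usual scatter, estimated at 20 mL.min-1.g-1 with a range from 10 mL.min-1.g-1 to 45 mL.min-1.g-1. The step of a 1.2-fold higher number from compound 1 to compound 4 (0.07 log units; within the scatter) is accordingly expected to be small, in either direction.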

Compound 4, intrinsic clearance in microsomes: < 16 mL.min-1.g-1
Compound 4 was reported as a limit; the forecaster's own chance of this, stated with the estimate: 25%; at least 1.2-fold (0.09 log units) between middle value and limit.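

The earlier compounds shown here offered only a step at this place that could not be read, whereas here this assay gives a first readable step: an at least 1.0-fold lower number from compound 1 to compound 4 (0.02 log units; that floor lies within the scatter). Replacing (pyridin-2-yl)methyl with phenyl removes the ring nitrogen and shortens the group by one heavy atom, yet the result gives no sign that clearance rises beyond the scatter, so compound 1 and compound 4 cannot be told apart on these data. Compound 4 gives < 16 mL.min-1.g-1, a limit of the assay and not a number, so the true size of the step stays hidden, and this result adds a second floor to the one reached by compound 2 and compound 3: the limit of < 16 mL.min-1.g-1 in this assay, at which 1 of the 4 values shown sits.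

Since both the ring nitrogen and the chain carbon change in this one step, the compounds shown do not separate their contributions, which a benzyl or a pyridin-2-yl group at this place could address. They also leave open whether a carboxylic acid or an amine on the ring at this place would give a reading clear of the floor.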